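The source may hold more compounds than are shown below. What is called first, only, known or untested is meant among the compounds shown, and "the series" means these compounds.

Compound 1 has the structure `O=S(=O)(Nc1ccc(-c2nc3ccccc3o2)cc1)c1ccc(Cl)c(C(F)(F)F)c1`. In an assay on isolated protein for inhibition of malate dehydrogenase, mitochondrial (Sus scrofa), with stated times of 45 min and 30 min (a higher number here means a weaker inhibitor, a lower number a stronger inhibitor), compound 1 gives > 63000 nM, which is a limit of the assay and not a number. Compound 2 has the structure `Cc1ccccc1S(=O)(=O)Nc1ccc2oc(-c3ccccc3)nc2c1`. In this assay compound 2 gives > 63000 nM, again a limit. Compound 3 has the structure `O=S(=O)(Nc1ccc2oc(-c3ccccc3)nc2c1)c1ccccc1F`. In this assay compound 3 gives > 63000 nM, likewise a limit.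

Compound 3 therefore stands at the limit, where all three measured compounds sit (the limit of > 63000 nM in this assay, at which 3 of the 3 values shown sit). Among the compounds with values here, the one single-point change among them, a step that the two limits leave unreadable from compound 2 to compound 3, cannot be read, since both ends of it are limits.

Compound 4 has the structure `COc1ccc(S(=O)(=O)Nc2ccc3oc(-c4ccccc4)nc3c2)cc1`. It differs from compound 3 in one place: 4-methoxyphenyl in place of 2-fluorophenyl on a sulfonyl sulfur. Within the data shown here, no measured step bears on this change, and no measured step has a readable size at all. The only guide is that every compound shown so far returned a limit in this assay. Compound 4 is therefore expected to return a limit as well, with an estimate of 100000 nM in a range from 30000 nM to 400000 nM. The expected step that the limit leaves unreadable from compound 3 to compound 4 is thus none beyond the scatter.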

Compound 4, half-maximal inhibitory concentration: > 63000 nM
Compound 4: only a limit was reported; the forecaster's own chance of this, stated with the estimate: 85%; the middle value does not contradict the limit.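

In this assay compound 4 gives > 63000 nM, a limit of the assay and not a number. Its steps from compound 2 and from compound 3 therefore cannot be read, as both ends of each are limits. The compounds shown leave open whether any group on the sulfonyl sulfur gives a readable inhibition.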